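The source may hold more compounds than are shown below. What is called first, only, known or untested is meant among the compounds shown, and "the series" means these compounds.

Working notes on the series in a functional assay on HepG2 cells (Homo sapiens) for inhibition, read by MTT assay, with a stated time of 72 h; on this read-out higher numbers stand for weaker inhibition and lower numbers for stronger inhibition: compound 1 `Clc1ccc(-c2nnc(SCCCN3CCN(c4nc5ccccc5s4)CC3)o2)cc1` gives 87700 nM and compound 2 `Oc1ccc(-c2nnc(SCCCN3CCN(c4nc5ccccc5s4)CC3)o2)cc1` gives 364000 nM, the higher of the two numbers. Compound 3 `O=C(NCc1nnc(SCCCN2CCN(c3nc4ccccc4s3)CC2)o1)c1ccccc1` carries benzamidomethyl in place of 4-hydroxyphenyl on an aromatic carbon. Going by the values given here, the one measured step is a 4.2-fold higher number from compound 1 to compound 2 (0.62 log units; beyond the scatter) for hydroxy in place of chloro, a modest step that bears on this change only loosely. A step of similar size toward a lower number is therefore expected in this assay, with wide uncertainty. The expected step is a 2.4-fold lower number from compound 2 to compound 3 (0.39 log units; beyond the scatter) at the estimate. Compound 3 is estimated at 150000 nM within a range of 50000 nM to 420000 nM overall.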

Compound 3, half-maximal inhibitory concentration: 325000 nM
Compound 3: the middle estimate sits 2.2-fold (0.34 log units) below what was measured; the measured number falls inside the stated range.
By their numbers in this assay, from the lowest: compound 1; then compounds 3 and 2 (each within the scatter of the next).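

Replacing 4-hydroxyphenyl with benzamidomethyl on this aromatic carbon gives a 1.1-fold lower number from compound 2 to compound 3 (0.05 log units; within the scatter) in this assay and so separates neither group from the other, despite the different group entering. Benzamidomethyl in place of 4-chlorophenyl gives a 3.7-fold higher number from compound 1 to compound 3 (0.57 log units; beyond the scatter) here, so compound 1 remains the only one of the three with a number clearly lower than the others. No measurement available explains these results.

Going by these compounds, whether an aminomethyl group or a carboxylic acid on this carbon would give a number lower than that of compound 1 remains open.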